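From Compound 2 to Compound 4: One Group Exchanged

The source may report more compounds than this note shows. Statements on the series, on what has been measured and on what is new or still open speak of the compounds shown alone.

Cytotoxicity in this small set of compounds was followed in a functional assay on Hs 766 cells (Homo sapiens) for cytotoxicity, read by MTT assay; on this read-out lower numbers stand for stronger inhibition and higher numbers for weaker inhibition. Compound 1 `O=C(NC(=O)c1ccccc1)Nc1ccc(Oc2ncccn2)cc1` offers no figure, and its entry reads "not determined" (no result reported). Compound 2 `O=C(NC(=S)Nc1ccc(Oc2ncccn2)cc1)c1ccccc1` likewise gives "not determined" (no result reported), so it stands without a single number, as does compound 1. Compound 3 `O=C(NC(=O)c1ccccc1)Nc1ccc(Sc2ncc(Br)cn2)cc1` is the only one with a measured result: in this assay compound 3 gives 5500 nM.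

Compound 4 `O=C(NC(=S)Nc1ccc(Sc2ncc(Br)cn2)cc1)c1ccccc1` has yet to be measured. It arises from compound 2 through a single exchange: (5-bromopyrimidin-2-yl)sulfanyl in place of (pyrimidin-2-yl)oxy on an aromatic carbon. Here (5-bromopyrimidin-2-yl)sulfanyl stands in place of (pyrimidin-2-yl)oxy on an aromatic carbon of a six-membered aromatic ring of carbon only, para to a large group. With no number for compound 2, the size of this step cannot be read from the data. The nearest guide is compound 3 at 5500 nM, which carries the same (5-bromopyrimidin-2-yl)sulfanyl group. Compound 4 is therefore expected to lie close to that result in this assay, with no step beyond the scatter and no firm direction. Compound 4 is estimated at 4500 nM, with an expected range from 1500 nM to 13000 nM.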

Compound 4, half-maximal inhibitory concentration: 8500 nM
Compound 4: the middle estimate sits 1.9-fold (0.28 log units) below what was measured; low and high end bracket the measured number.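

Going by these compounds alone, compound 2 stands without a single number in this assay and so no step to compound 4 can be read, which leaves compound 4 at 8500 nM as a lone value. Nothing at hand bears on the reason for this result. The compounds shown leave open how far exchanging (pyrimidin-2-yl)oxy for (5-bromopyrimidin-2-yl)sulfanyl shifts cytotoxicity.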